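Bromo to fluoro on the benzyl group of compound 3

The source may report more compounds than this note shows. Statements on the series, on what has been measured and on what is new or still open speak of the compounds shown alone.

In a functional assay on MCF7 cells (Homo sapiens) for cytotoxicity, read by MTT assay, with a stated time of 48 h (on this read-out higher numbers stand for weaker inhibition and lower numbers for stronger inhibition), three chalcone ethers share one core. Compound 1 `COc1ccc(C(=O)/C=C/c2ccc(OCc3cn(Cc4ccccc4)nn3)cc2)cc1` gives 5000 nM. Compound 2 `COc1ccc(C(=O)/C=C/c2ccc(OCc3cn(Cc4ccccc4Br)nn3)cc2)cc1` gives 7000 nM, and the step of a 1.4-fold higher number from compound 1 to compound 2 (0.15 log units; within the scatter) is small. Compound 3 `COc1ccc(C(=O)/C=C/c2ccc(OCc3cn(Cc4cccc(Br)c4)nn3)cc2)cc1` gives 20000 nM, the highest number of the three, with a 4.0-fold higher number from compound 1 to compound 3 (0.60 log units; beyond the scatter) and a 2.9-fold higher number from compound 2 to compound 3 (0.46 log units; beyond the scatter) both beyond the scatter. Compound 4 `COc1ccc(C(=O)/C=C/c2ccc(OCc3cn(Cc4cccc(F)c4)nn3)cc2)cc1` is not yet measured; it differs from compound 3 by fluoro in place of bromo on an aromatic carbon. Within the data shown here, no measured step here exchanges one halogen for another, so the nearest guide is the step of a 4.0-fold higher number from compound 1 to compound 3 (0.60 log units; beyond the scatter), where bromo entered at the same place on the ring. Since that bromo raised the number, its replacement by fluoro is expected to bring compound 4 partway back toward compound 1, a modest step downward in this assay, a 2.0-fold lower number from compound 3 to compound 4 (0.30 log units; within the scatter), though the direction is uncertain. Compound 4 is therefore estimated at 10000 nM, in a range from 4000 nM to 25000 nM.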

Compound 4, half-maximal inhibitory concentration: 55000 nM
Compound 4: the middle estimate sits 5.5-fold (0.74 log units) below what was measured, and the stated range ends below it.
By their numbers in this assay, from the lowest: compounds 1 and 2 (each within the scatter of the next); then compound 3; then compound 4.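

In this assay the identity of the halogen on this aromatic carbon matters, and fluoro in place of bromo does not lead back toward the unsubstituted benzyl compound: the move goes the other way, with a 2.8-fold higher number from compound 3 to compound 4 (0.44 log units; beyond the scatter) on this exchange alone. Against hydrogen, both halogens at this place raise the number, but fluoro goes further, with an 11-fold higher number from compound 1 to compound 4 (1.04 log units; beyond the scatter) as a large step and a 4.0-fold higher number from compound 1 to compound 3 (0.60 log units; beyond the scatter) as only a modest one. Compound 4 now has the highest number of the series, and even compound 2, with its 2-bromophenyl group, stands well apart, with a 7.9-fold higher number from compound 2 to compound 4 (0.90 log units; beyond the scatter) in this assay.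

Nothing in hand explains why fluoro stands above bromo here. From the compounds shown here alone, whether chloro or a methoxy group on this same carbon would fall near bromo, near fluoro or elsewhere remains open.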